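Trifluoromethoxy Added to a Pyridyl Ether Thymine Analogue

The source may report more compounds than this note shows. Statements on the series, on what has been measured and on what is new or still open speak of the compounds shown alone.

Compound 1 `Cc1cn(C2CCN(Cc3cccc(Oc4cccc(Cl)c4)c3)CC2)c(=O)[nH]c1=O` and compound 2 `Cc1cn(C2CCN(Cc3cncc(Oc4ccccc4)c3)CC2)c(=O)[nH]c1=O` share the same core but differ in more than one place, so only their two values can be compared. In an ADME assay on MRC5 cells (Homo sapiens) for cytotoxicity, read by fluorescence and resazurin assay, with a stated time of 3 days (on this read-out lower numbers stand for stronger inhibition and higher numbers for weaker inhibition), compound 1 gives 21000 nM. For compound 2 this assay reports only a limit, > 64000 nM. Compound 2 therefore stands at the limit of > 64000 nM in this assay, at which 1 of the 2 values shown sits, and has no number of its own. Compound 3 `Cc1cn(C2CCN(Cc3cncc(Oc4cccc(OC(F)(F)F)c4)c3)CC2)c(=O)[nH]c1=O` differs from compound 2 by trifluoromethoxy in place of hydrogen on an aromatic carbon. Going by the values given here, no measured step covers this change. Compound 3 is expected to remain weakly cytotoxic, with an expected step of an at least 1.4-fold lower number from compound 2 to compound 3 (0.15 log units; that floor lies within the scatter) that may not exceed the scatter. Compound 3 is estimated at 45000 nM, between 15000 nM and 100000 nM.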

Compound 3, half-maximal inhibitory concentration: > 64000 nM
Compound 3: a limit, no number (the forecaster's own chance of this, stated with the estimate: 55%); middle value at least 1.4-fold (0.15 log units) from the limit.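

No step can be read from compound 2 to compound 3 in this assay, since each gives only a limit and no number: the limit of > 64000 nM in this assay, at which 2 of the 3 values shown sit.

The compounds shown leave open whether trifluoromethoxy in place of hydrogen on an aromatic carbon shifts this read-out at all.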